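The source may hold more compounds than are shown below. What is called first, only, known or untested is meant among the compounds shown, and "the series" means these compounds.

Compound 1 `O=C(O)c1ccccc1-c1ccc(CCc2ncc(C3CCCCC3)[nH]2)cc1` is the starting point. In an in vitro functional assay on cells for agonist activity at Bombesin receptor subtype-3 (Homo sapiens), read by luminescence and calcium flux (on this read-out lower numbers stand for an effect already at smaller amounts and higher numbers for an effect only at larger amounts of compound), compound 1 gives 375 nM, the second highest of three numbers. Compound 2 `Cc1ccccc1Cc1cnc(CCc2ccc(-c3ccccc3C(=O)O)cc2)[nH]1` gives 127 nM, and the step of a 3.0-fold lower number from compound 1 to compound 2 (0.47 log units; beyond the scatter) is modest. Compound 3 `COc1ccc(Cc2cnc(CCc3ccc(-c4ccccc4C(=O)O)cc3)[nH]2)cc1` gives 5360 nM, and the step of a 14-fold higher number from compound 1 to compound 3 (1.16 log units; beyond the scatter) is large. The new compound 4 `CC(C)CCc1cnc(CCc2ccc(-c3ccccc3C(=O)O)cc2)[nH]1` differs from compound 1 in one place: isopentyl in place of cyclohexyl on an aromatic carbon. Both measured steps swap the cyclohexyl for a group carrying a ring, whereas isopentyl has none, and the two steps point in opposite directions, one modest and one large. A small move, if any, is therefore expected. Compound 4 is estimated at 450 nM, between 150 nM and 1400 nM. The expected step of a 1.2-fold higher number from compound 1 to compound 4 (0.08 log units; within the scatter) stays within the scatter.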

Compound 4, half-maximal effective concentration: 119 nM
Beside the measured number, compound 4's estimate is 3.8-fold (0.58 log units) above it, outside the stated range (below it).
By their numbers in this assay, from the lowest: compounds 4 and 2 (each within the scatter of the next); then compound 1; then compound 3.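

Replacing cyclohexyl with isopentyl gives (a 3.2-fold lower number from compound 1 to compound 4 (0.50 log units; beyond the scatter)), so a group with no ring can work at this position on the five-membered aromatic ring. Set against the ring-bearing side groups, the chain gives (a 1.1-fold lower number from compound 2 to compound 4 (0.03 log units; within the scatter)) and (a 45-fold lower number from compound 3 to compound 4 (1.65 log units; beyond the scatter)), which shows that the open chain and the 2-methylbenzyl group sit level, while compound 3 stays far apart. Nothing measured here explains these differences. As far as these compounds go, whether a shorter chain such as ethyl, or a chain ending in an amine or a carboxylic acid, would keep these numbers remains open.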